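A few compounds are considered here, and "the series" means these few. Any claim that something is new, unique, unknown or untested is made for them only; others in the source may bear on it.

Measured compounds:
- compound 1, `Cc1cc([C@H](C(=O)NC(C)C)N2C(=O)[C@@H](C3Cc4ccccc4C3)NC(=O)[C@H]2CC(C)C)oc1C`, an assay on isolated protein for binding affinity to Oxytocin receptor (Homo sapiens); on this read-out lower numbers stand for stronger inhibition and higher numbers for weaker inhibition: 1.26 nM
- compound 2, `CC(C)C[C@@H]1C(=O)N[C@H](C2Cc3ccccc3C2)C(=O)N1[C@@H](C(=O)NC(C)C)c1ccc(Br)s1`, this assay: 2 nM

Compound 2 stands beside compound 1 in this assay: the two are separated only by a 1.6-fold higher number from compound 1 to compound 2 (0.20 log units; within the scatter), a gap within the scatter, so neither can be called the stronger binder. That single step is the only one measured, and it already involves a swap of the aryl group on the saturated chain carbon bound to an amide-type nitrogen in a ring and a carbonyl carbon, from 4,5-dimethylfuran-2-yl to 5-bromothiophen-2-yl, without a shift beyond the scatter.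

Compound 3, `Cc1nc([C@H](C(=O)NC(C)C)N2C(=O)[C@@H](C3Cc4ccccc4C3)NC(=O)[C@H]2CC(C)C)co1`, is not yet measured. It differs from compound 2 as follows: 2-methyl-1,3-oxazol-4-yl in place of 5-bromothiophen-2-yl on a saturated chain carbon bound to an amide-type nitrogen in a ring and a carbonyl carbon. For the measured compounds named here, the only comparison that bears on this change is the aryl swap from compound 1 to compound 2, which was a 1.6-fold higher number from compound 1 to compound 2 (0.20 log units; within the scatter). On that basis no step beyond the scatter is expected in this assay for compound 3 in either direction. Compound 3 is therefore estimated at 2.2 nM, between 0.7 nM and 7 nM, which corresponds to an expected step of a 1.1-fold higher number from compound 2 to compound 3 (0.04 log units; within the scatter).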

Compound 3, inhibition constant in the Oxytocin receptor assay: 1.26 nM
Beside the measured number, compound 3's estimate is 1.7-fold (0.24 log units) above it; measured number inside the range.
By their numbers in the Oxytocin receptor assay, from the lowest: compounds 1, 3 and 2 (each within the scatter of the next).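

In the Oxytocin receptor assay, the position on a saturated chain carbon bound to an amide-type nitrogen in a ring and a carbonyl carbon accepts 2-methyl-1,3-oxazol-4-yl with no shift beyond the scatter: a 1.6-fold lower number from compound 2 to compound 3 (0.20 log units; within the scatter), and no change at the digits printed from compound 1 to compound 3 (within the scatter), so the three groups seen here cannot be told apart by this read-out. For the compounds shown here, in a physicochemical assay for solubility (on this read-out higher numbers stand for higher solubility and lower numbers for lower solubility), the same change from 5-bromothiophen-2-yl to 2-methyl-1,3-oxazol-4-yl gives the first step beyond the scatter at this position: the measured solubility of compound 2, < 1 ug/mL, and of compound 3, > 240 ug/mL, an at least 240-fold higher number (2.38 log units; beyond the scatter) In the physicochemical assay, compound 2 gives < 1 ug/mL, which is a limit of the assay and not a number. In the physicochemical assay, compound 3 gives > 240 ug/mL, which is also a limit of the assay and not a number. The step therefore marks only a minimum size.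

The two compounds compared for solubility differ in the whole ring group, so the compounds shown leave open whether the step goes with the loss of the bromine, the sulfur or the thiophene ring itself, or with the entry of the ring nitrogen and oxygen. They also leave open whether a pyridine ring, or a thiophene carrying a methyl group in place of the bromine, would hold the number in the Oxytocin receptor assay and how it would read in the physicochemical assay.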